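The compounds below may be only part of what the source reports. "The series", "measured", "known", "first", "only" and "open" are said of these compounds alone.

Of the compounds shown here, two have so far been read in a functional assay on NCI-H23 cells (Homo sapiens) for cytotoxicity, read by sulforhodamine B assay, with a stated time of 72 h (a higher number here means a weaker inhibitor of growth, a lower number a stronger inhibitor of growth), and only one gives a number. Compound 1 `O=C(Nc1ccc(O)cc1)C1CCc2ccccc2N1` gives > 100000 nM in this assay as a limit and not as a number. Among the measured compounds shown here, compound 2 `O=C(Nc1cc(C(F)(F)F)cc(C(F)(F)F)c1)C1CCc2ccccc2N1C(=O)c1ccc(Cl)cc1` gives 889 nM in this assay and is the only compound with a measured value. For the measured compounds named here, the two compounds are not related by a single change, so no measured step is available.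

Compound 3 `O=C(Nc1cc(C(F)(F)F)cc(C(F)(F)F)c1)C1CCc2ccccc2N1C(=O)c1cccc(Cl)c1` has the same atoms as compound 2, joined differently: 3-chlorophenyl in place of 4-chlorophenyl on a carbonyl carbon. Going by the values given here, no pair shows what this change does in this assay and the only anchor for the expectation is compound 2 at 889 nM with the counts of the exchanged group left unchanged. The expected step of a 1.2-fold higher number from compound 2 to compound 3 (0.09 log units; within the scatter) is small and within the usual scatter, with no firm direction. For compound 3 the estimated value is 1100 nM with an expected range from 350 nM to 3000 nM in this assay.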

Compound 3, concentration for 50% growth inhibition: 420 nM
Beside the measured number, compound 3's estimate is 2.6-fold (0.42 log units) above it; low and high end bracket the measured number.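

In this assay, among the compounds shown here, 3-chlorophenyl in place of 4-chlorophenyl on a carbonyl carbon gives a 2.1-fold lower number from compound 2 to compound 3 (0.33 log units; beyond the scatter) and this modest change is the only measured step. Both groups have the same heavy-atom count and the same ring, with no hydrogen-bond donor or acceptor and no net charge on either side, so the way the same atoms are joined at this place is enough to move the number beyond the scatter. Nothing measured here bears on what lies behind this step, and it remains an observation on a single pair of compounds.

Still open, from the compounds shown here alone, is whether the preference for 3-chlorophenyl over 4-chlorophenyl belongs to chlorine alone or would also appear with a fluorine, a methyl or a methoxy group in the same place, or with an amine or a carboxylic acid in place of the chlorine. Also open, going by these compounds, is whether the same step would be seen with the bis(trifluoromethyl)phenyl amide exchanged for another group, such as a simple phenyl, since every comparison so far rests on that one amide.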